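Series notes: bromo for nitro, expectation for compound 4

This account rests on a few compounds, and the source may have more. Where it says the series, first, only, none or still open, it means among the compounds named here.

Compound 1, `O=[N+]([O-])c1ccc(Cn2cc(COc3ccccc3)nn2)cc1`: in an ADME assay on PANC-1 cells (Homo sapiens) for inhibition, read by MTT assay, with a stated time of 48 h (a higher number here means a weaker inhibitor of growth, a lower number a stronger inhibitor of growth), compound 1 gives > 100 ug/mL, which is a limit of the assay and not a number.
Compound 2, `Brc1ccc(Cn2cc(COc3ccccc3)nn2)cc1`: in this assay compound 2 gives > 100 ug/mL, again a limit.
Compound 3, `O=[N+]([O-])c1ccc(Cn2cc(COc3ccc(Cl)cc3)nn2)cc1`: in this assay compound 3 gives > 100 ug/mL, again a limit.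

Compound 3 therefore stands at the limit of this assay, and so do the other two values shown; the whole set sits at the limit of > 100 ug/mL in this assay, at which 3 of the 3 values shown sit. Neither measured step is readable: the change of bromo for nitro gives a step that the two limits leave unreadable from compound 1 to compound 2, and the change of chloro for hydrogen gives a step that the two limits leave unreadable from compound 1 to compound 3. No numbered value is available in the series.

Compound 4, `Clc1ccc(OCc2cn(Cc3ccc(Br)cc3)nn2)cc1`, differs from compound 3 as bromo in place of nitro on an aromatic carbon. Among the measured compounds shown here, the only step that bears on this change is the one from compound 1 to compound 2, the same exchange of bromo for nitro, and its size could not be read from the two limits. Compound 2, which already carries the bromo group, sits at the limit in this assay, as does compound 3.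

On that basis the step is expected to be a step that the limit leaves unreadable from compound 3 to compound 4, with no readable direction. Compound 4 is estimated to give 150 ug/mL in this assay, with a range from 50 ug/mL to 500 ug/mL, and most likely only a limit again.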

Compound 4, concentration for 50% growth inhibition: > 100 ug/mL
Compound 4: only a limit was reported; the forecaster's own chance of this, stated with the estimate: 85%; the middle value is on the limit's open side.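

Compound 4 gives > 100 ug/mL in this assay, which is a limit and not a number. No new step can be read from compound 4 to compound 2 or compound 3, as all the values shown are limits: the limit of > 100 ug/mL in this assay, at which 4 of the 4 values shown sit.

The compounds shown leave open the direction and size of both the bromo for nitro and the chloro for hydrogen changes.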